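This account rests on a few compounds, and the source may have more. Where it says the series, first, only, none or still open, it means among the compounds named here.

In a functional assay for inhibition, with Homo sapiens as the target (on this read-out lower numbers stand for stronger inhibition and higher numbers for weaker inhibition), compound 1 `Cc1c(Cc2cccnc2)cc2c(c1CCC(=O)O)CCC(NS(=O)(=O)c1ccc(Cl)cc1)C2` gives 610 nM and compound 2 `O=C(O)CCc1c2c(cc(Cc3cccnc3)c1-c1ccccc1)CC(NS(=O)(=O)c1ccc(Cl)cc1)CC2` gives 180 nM. Among the compounds with values here, this pair provides the only measured step that differs in one place: a 3.4-fold lower number from compound 1 to compound 2 (0.53 log units; beyond the scatter), with phenyl in place of methyl on an aromatic carbon. Compound 3 `O=C(O)CC/C=C/c1c(Cc2cccnc2)ccc2c1CCC(NS(=O)(=O)c1ccc(Cl)cc1)C2` gives 47 nM, the lowest of the three numbers and beyond the scatter from both of the others.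

Compound 4 `O=C(O)CCC/C=C/c1c(Cc2cccnc2)ccc2c1CCC(NS(=O)(=O)c1ccc(Cl)cc1)C2` departs from compound 3 through (carboxymethyl in place of carboxy on a saturated chain carbon, two bonds along the chain from a double-bonded chain carbon). This is carboxymethyl in place of carboxy on a saturated chain carbon, two bonds along the chain from a double-bonded chain carbon, which also reads as 4-carboxybut-1-en-1-yl to 5-carboxypent-1-en-1-yl.

Within the data shown here, no measured step covers a change of this kind. The step of a 3.4-fold lower number from compound 1 to compound 2 (0.53 log units; beyond the scatter) concerns a group on an aromatic carbon rather than the acid chain, so it offers only a loose guide to size and none to direction. The expectation therefore stays anchored on compound 3 at 47 nM, and no step beyond the scatter is expected. The expected result is a 1.1-fold higher number from compound 3 to compound 4 (0.03 log units; within the scatter). For compound 4 the estimated value is 50 nM, with an expected range from 17 nM to 150 nM.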

Compound 4, half-maximal inhibitory concentration: 450 nM
Beside the measured number, compound 4's estimate is 9.0-fold (0.95 log units) below it; the measured number lies above the stated range.
By their numbers in this assay, from the lowest: compound 3; then compound 2; then compounds 4 and 1 (each within the scatter of the next).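

The acid chain turns out to be sensitive to its length: in this assay the change from 4-carboxybut-1-en-1-yl to 5-carboxypent-1-en-1-yl gives a 9.6-fold higher number from compound 3 to compound 4 (0.98 log units; beyond the scatter), a shift beyond the scatter towards weaker inhibition. Within the data shown here, the only earlier step concerned a group on an aromatic carbon, so this is the first direct reading on the chain that carries the acid, and here the rest of the structure, including the double bond, stays the same. No measurement given here explains why the added carbon weakens inhibition.

Among these compounds, the two chain lengths give only one step, so it remains open whether a shorter chain such as 3-carboxyprop-1-en-1-yl would continue the trend in the opposite direction or whether 4-carboxybut-1-en-1-yl is the best length. Also unresolved is whether a longer chain such as 6-carboxyhex-1-en-1-yl would weaken inhibition further, and whether a tetrazole could stand in for the carboxylic acid at the end of the chain.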